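Replacing fluoro with amino on the methoxyphenyl group

The source may hold more compounds than are shown below. What is called first, only, known or untested is meant among the compounds shown, and "the series" means these compounds.

Of the compounds shown here, three that share one core have been measured in a functional assay on MCF7 cells (Homo sapiens) for inhibition, read by CCK-8 assay, with a stated time of 48 h; on this read-out higher numbers stand for weaker inhibition and lower numbers for stronger inhibition. Compound 1 `COc1cc(-c2ccnc3cc(-c4ccc(C)c(C)c4)nn23)cc(OC)c1OC`, bearing 3,4-dimethylphenyl, gives 26 nM. Compound 2 `COc1cc(-c2ccnc3cc(-c4ccc5ccn(C)c5c4)nn23)cc(OC)c1OC`, bearing 1-methyl-1H-indol-6-yl, gives 74 nM. Compound 3 `COc1ccc(-c2cc3nccc(-c4cc(OC)c(OC)c(OC)c4)n3n2)cc1F`, bearing 3-fluoro-4-methoxyphenyl, gives 183 nM, the highest number of the three and so the weakest inhibition so far.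

Compound 4 `COc1ccc(-c2cc3nccc(-c4cc(OC)c(OC)c(OC)c4)n3n2)cc1N` differs from compound 3 in a single substituent: amino in place of fluoro on an aromatic carbon. Amino stands in place of fluoro, ortho to a methoxy group, which turns 3-fluoro-4-methoxyphenyl into 3-amino-4-methoxyphenyl.

Going by the values given here, no measured pair makes this exact swap, so the evidence is indirect. The closest guides are exchanges of the whole group: a 7.0-fold higher number from compound 1 to compound 3 (0.85 log units; beyond the scatter) and a 2.5-fold higher number from compound 2 to compound 3 (0.39 log units; beyond the scatter), along with a 2.8-fold higher number from compound 1 to compound 2 (0.45 log units; beyond the scatter). All three are modest but beyond the scatter, so changes in this part of the molecule do register in this assay. Compound 3 also sits at the top of the measured values, and both other compounds lie lower, so a modest move down seems more likely than a move up, though this is only a weak lean. The expected change is a 2.3-fold lower number from compound 3 to compound 4 (0.36 log units; beyond the scatter), similar in size to those steps. For compound 4 the estimated value is 80 nM, with an expected range from 20 nM to 300 nM.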

Compound 4, half-maximal inhibitory concentration: 27 nM
Compound 4: the middle estimate sits 3.0-fold (0.47 log units) above what was measured; measured number inside the range.
By their numbers in this assay, from the lowest: compounds 1 and 4 (each within the scatter of the next); then compound 2; then compound 3.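

Exchanging a single fluoro for amino, ortho to a methoxy group, gives a 6.8-fold lower number from compound 3 to compound 4 (0.83 log units; beyond the scatter) in this assay and shows that this one spot on the ring is sensitive to which atom it carries; the shift is about as large as a 7.0-fold higher number from compound 1 to compound 3 (0.85 log units; beyond the scatter) for replacing the whole group. The 3-amino-4-methoxyphenyl group also compares well with the bicyclic group of compound 2, with a 2.7-fold lower number from compound 2 to compound 4 (0.44 log units; beyond the scatter) as the step, while against 3,4-dimethylphenyl the result is a 1.0-fold higher number from compound 1 to compound 4 (0.02 log units; within the scatter) and so the two groups cannot be told apart here, although they look quite different. Nothing available here explains why amino and fluoro differ so clearly at this position.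

On these data alone, it remains open whether other groups at this spot, such as hydroxyl, methylamino, dimethylamino or acetamido, would match amino or fall back toward fluoro. The compounds shown also leave open how much the neighbouring methoxy group contributes, which a compound carrying ethoxy or hydroxyl there, with the amino kept in place, could help to answer.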